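From 3-(dimethylamino)propyl to 3-(diethylamino)propyl

A few compounds are considered here, and "the series" means these few. Any claim that something is new, unique, unknown or untested is made for them only; others in the source may bear on it.

Measured in a functional assay on K562 cells (Homo sapiens) for antiproliferative activity, read by MTT assay, with a stated time of 48 h; a lower number here means a stronger inhibitor, a higher number a weaker inhibitor:
Compound 1 `CN(C)CCn1c(N)c(-c2nc3ccccc3n2C)c2nc(C#N)c(C#N)nc21`: > 50000 nM (a limit)
Compound 2 `CCN(CC)CCn1c(N)c(-c2nc3ccccc3n2C)c2nc(C#N)c(C#N)nc21`: > 50000 nM (a limit)
Compound 3 `CN(C)CCCn1c(N)c(-c2nc3ccccc3n2C)c2nc(C#N)c(C#N)nc21`: 3560 nM

Within the data shown here, compound 3 stands at 3560 nM, the only true number of the three. The values of compound 1 and compound 2 are limits. Compound 4 `CCN(CC)CCCn1c(N)c(-c2nc3ccccc3n2C)c2nc(C#N)c(C#N)nc21` carries diethylamino in place of dimethylamino on a saturated chain carbon, three bonds along the chain from an aromatic nitrogen. The same exchange two bonds along the chain is a step that the two limits leave unreadable from compound 1 to compound 2, so it offers no size to carry over. The large steps, an at least 14-fold lower number from compound 1 to compound 3 (1.14 log units; beyond the scatter) and an at least 14-fold lower number from compound 2 to compound 3 (1.14 log units; beyond the scatter), both lengthen the chain, which compound 4 does not change further. No step beyond the scatter is therefore expected in this assay. The expected step is a 1.1-fold higher number from compound 3 to compound 4 (0.05 log units; within the scatter). Compound 4 is estimated at 4000 nM, within 1300 nM to 15000 nM.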

Compound 4, half-maximal inhibitory concentration: 3270 nM
Compound 4: middle estimate off by 1.2-fold (0.09 log units), on the high side; the range from low to high includes it.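

In this assay the exchange of dimethylamino for diethylamino can now be read, at three bonds along the chain from an aromatic nitrogen, and a 1.1-fold lower number from compound 3 to compound 4 (0.04 log units; within the scatter) shows that it changes nothing measurable there. With an at least 15-fold lower number from compound 2 to compound 4 (1.18 log units; beyond the scatter) and an at least 15-fold lower number from compound 1 to compound 4 (1.18 log units; beyond the scatter) as the large steps, the 3-(diethylamino)propyl chain stands clearly apart from both shorter compounds, so the large gap holds for diethylamino too. Compound 1 and compound 2 each give a limit, so these two steps are minimum sizes only: the limit of > 50000 nM in this assay, at which 2 of the 4 values shown sit.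

Still open, on these data alone, is whether a longer chain, or a ring amine such as piperidine or morpholine at the chain end, would keep this level in this assay or move it.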